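Shortening the Carbonyl Chain of a Compound at the Limit

The source may report more compounds than this note shows. Statements on the series, on what has been measured and on what is new or still open speak of the compounds shown alone.

Compound 1 `CCCCCCCCC(=O)N1c2ccccc2CCC1C(=O)Nc1ccccc1C(F)(F)F` carries an octyl group on a carbonyl carbon, and compound 2 `O=C(Nc1ccccc1C(F)(F)F)C1CCc2ccccc2N1C(=O)c1ccccc1Cl` carries a 2-chlorophenyl there instead. In a functional assay on MDA-MB-231 cells (Homo sapiens) for cytotoxicity, read by sulforhodamine B assay, with a stated time of 72 h (a lower number here means a stronger inhibitor of growth, a higher number a weaker inhibitor of growth), compound 1 gives 3350 nM, and compound 2 gives 2530 nM. Compound 3 `CCCC(=O)N1c2ccccc2CCC1C(=O)Nc1ccccc1C(F)(F)F` has a much shorter chain on that carbonyl. In this assay compound 3 gives no number, only > 70000 nM, which is the limit of > 70000 nM in this assay, at which 1 of the 3 values shown sits. The steps of an at least 20-fold higher number from compound 1 to compound 3 (1.32 log units; beyond the scatter) and an at least 27-fold higher number from compound 2 to compound 3 (1.44 log units; beyond the scatter) show that cutting this chain down removes measurable growth inhibition. Compound 4 `CC(=O)N1c2ccccc2CCC1C(=O)Nc1ccccc1C(F)(F)F` cuts it down once more: hydrogen in place of ethyl on a saturated chain carbon bound to a carbonyl carbon. Since compound 3 already sits at the limit, the same outcome is expected. Compound 4 is estimated at 100000 nM, within 50000 nM to 300000 nM. The expected step that the limit leaves unreadable from compound 3 to compound 4 is essentially none, most likely another limit.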

Compound 4, concentration for 50% growth inhibition: > 80000 nM
Compound 4: only a limit was reported; the forecaster's own chance of this, stated with the estimate: 85%; the middle value lies beyond the limit too.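

Taking the chain down from propyl to methyl brings back no measurable growth inhibition in this assay, so the loss seen with compound 3 persists in compound 4. Against the two measured compounds, the result reads as an at least 23-fold higher number from compound 1 to compound 4 (1.37 log units; beyond the scatter) and an at least 31-fold higher number from compound 2 to compound 4 (1.49 log units; beyond the scatter). The step from compound 3 to compound 4 cannot be read, because each compound has only a limit, and that of compound 4 is: the limit of > 80000 nM in this assay, at which 1 of the 4 values shown sits.

Still open, as far as these compounds go, is which chain, from butyl up to heptyl, first restores a measurable value. From the compounds shown here alone, a decyl chain or an amine on that carbonyl also remains untested here.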